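Changing the Aryl Group on the Nitrogen-Bound Carbon

A few compounds are considered here, and "the series" means these few. Any claim that something is new, unique, unknown or untested is made for them only; others in the source may bear on it.

Measured compounds:
compound 1 `COc1ccc(-c2ccc3c(c2)C(=O)C(=O)N3Cc2ccccc2Cl)cc1` gives 600 nM
compound 2 `COc1ccc(-c2ccc3c(c2)C(=O)C(=O)N3Cc2ccc(C(F)(F)F)cc2)cc1` gives 380 nM

Both numbers come from a functional assay on HepG2 cells (Homo sapiens) for antiproliferative activity, read by MTT assay, with a stated time of 48 h; on this read-out lower numbers stand for stronger inhibition and higher numbers for weaker inhibition. Compound 2 sits at the lower of the two numbers, yet a 1.6-fold lower number from compound 1 to compound 2 (0.20 log units; within the scatter) shows that the gap between them does not exceed the usual scatter, so the two compounds cannot be told apart on this read-out.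

Compound 3 `COc1ccc(-c2ccc3c(c2)C(=O)C(=O)N3Cc2ccc3ccccc3c2)cc1` has not yet been measured. Its difference from compound 2 is naphthalen-2-yl in place of 4-(trifluoromethyl)phenyl on a saturated chain carbon bound to an amide-type nitrogen in a ring. Within the data shown here, the only measured step that touches the same place is a 1.6-fold lower number from compound 1 to compound 2 (0.20 log units; within the scatter), where one aryl group on that saturated chain carbon was exchanged for another without moving the number beyond the scatter. Among the measured compounds shown here, no measured compound carries a naphthalen-2-yl group, so nothing shows how two fused rings at this position behave.

On this basis compound 3 is expected to give about 400 nM in this assay, with a range from 150 nM to 1100 nM. The step this estimate implies is a 1.1-fold higher number from compound 2 to compound 3 (0.02 log units; within the scatter), meaning no change beyond the scatter is expected.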

Compound 3, half-maximal inhibitory concentration: 380 nM
For compound 3 the middle estimate is 1.1-fold (0.02 log units) above the measured one; the measured number falls inside the stated range.
By their numbers in this assay, from the lowest: compounds 2, 3 and 1 (each within the scatter of the next).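

In this assay, the saturated chain carbon bound to an amide-type nitrogen in a ring now also carries naphthalen-2-yl, which has a second six-membered aromatic ring of carbon only, and with this group in place of 4-(trifluoromethyl)phenyl there is no change at the digits printed from compound 2 to compound 3 (within the scatter) for this exchange. With the same group in place of 2-chlorophenyl there is a 1.6-fold lower number from compound 1 to compound 3 (0.20 log units; within the scatter), so these three different aryl groups cannot be told apart on this read-out, even though the earlier pair differed only in what sat on a single ring. No measurement here offers an explanation for this result.

Going by these compounds, all three groups are aromatic rings of carbon, so it remains open whether a ring containing nitrogen, such as pyridin-3-yl, a phenyl ring bearing a carboxylic acid, or a plain longer alkyl chain in place of the aryl group would give numbers within the same scatter. On these data alone, all three compounds also share one core, so it is equally open whether the same holds once the rest of the molecule differs.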